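Replacing the Aminocyclohexyl Group on a Furan-Bearing Compound

The compounds below may be only part of what the source reports. "The series", "measured", "known", "first", "only" and "open" are said of these compounds alone.

In a functional assay on MCF7 cells (Homo sapiens) for inhibition, with a stated time of 72 h (on this read-out lower numbers stand for stronger inhibition and higher numbers for weaker inhibition), compound 1 `COc1ccccc1-c1ccc(CNc2nc(NC3CCC(N)CC3)nc3c2ncn3C2CCCC2)cc1` gives 303 nM and compound 2 `NC1CCC(Nc2nc(NCc3ccc(-c4cccc(F)c4)cc3)c3ncn(C4CCCC4)c3n2)CC1` gives 293 nM, and a 1.0-fold lower number from compound 1 to compound 2 (0.01 log units; within the scatter) shows no real difference between them. Compound 3 `NC1CCC(Nc2nc(NCc3ccc(-c4ccco4)cc3)c3ncn(C4CCCC4)c3n2)CC1` has the lowest number of the three at 85 nM, making it the most potent so far. Its advantage appears in a 3.6-fold lower number from compound 1 to compound 3 (0.55 log units; beyond the scatter) and in a 3.4-fold lower number from compound 2 to compound 3 (0.54 log units; beyond the scatter), both modest and beyond the scatter.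

Compound 4 `CC(C)(O)CNc1nc(NCc2ccc(-c3ccco3)cc2)c2ncn(C3CCCC3)c2n1` keeps the furan-2-yl group of compound 3. Instead, 2-hydroxy-2-methylpropyl takes the place of 4-aminocyclohexyl on a nitrogen on an aromatic ring: 2-hydroxy-2-methylpropyl in place of 4-aminocyclohexyl on a nitrogen on an aromatic ring. All three measured steps swap the aromatic group, so none tests this nitrogen substituent directly. They offer only a rough yardstick for size, and the change here is expected to cost more than the gain in a 3.4-fold lower number from compound 2 to compound 3 (0.54 log units; beyond the scatter), with weaker inhibition as the likely direction. The expected change is a 5.9-fold higher number from compound 3 to compound 4 (0.77 log units; beyond the scatter) on this estimate. Compound 4 is estimated at 500 nM, with an expected range from 120 nM to 2500 nM in this assay as the read-out.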

Compound 4, half-maximal inhibitory concentration: 15300 nM
Compound 4: middle estimate off by 31-fold (1.49 log units), on the low side; measured number above the stated range.
By their numbers in this assay, from the lowest: compound 3; then compounds 2 and 1 (each within the scatter of the next); then compound 4.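

In this assay, this nitrogen substituent counts for far more than any of the aromatic swaps: placing 2-hydroxy-2-methylpropyl where 4-aminocyclohexyl stood gives the step (a 180-fold higher number from compound 3 to compound 4 (2.26 log units; beyond the scatter)), while the largest aromatic swap gave only a modest one (a 3.6-fold lower number from compound 1 to compound 3 (0.55 log units; beyond the scatter)). Keeping the furan-2-yl group therefore does not preserve potency once 4-aminocyclohexyl is gone, even though both groups count the same hydrogen-bond donors and acceptors and carry no net charge. Nothing available gives a measured reason for this loss.

Still open, going by these compounds, is whether the ring or its amine matters more: a plain cyclohexyl group would test the ring without the amine, and a 2-aminoethyl chain would test the amine without the ring. On these data alone, it is also open whether the same swap would cost as much alongside the 3-fluorophenyl group.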